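Series notes: fluoro for methyl on two related cores

This account rests on a few compounds, and the source may have more. Where it says the series, first, only, none or still open, it means among the compounds named here.

Measured so far:
compound 1 `Cc1ccc(-c2ccc(C)n2-c2ccc(-c3nc4ccccc4s3)cc2)cc1` — 3100 nM
compound 2 `Cc1ccc(-c2ccc(F)cc2)n1-c1ccc(-c2nc3ccccc3s2)cc1` — 3180 nM
compound 3 `COc1ccc2nc(-c3ccc(-n4c(C)ccc4-c4ccc(C)cc4)cc3)sc2c1` — 2850 nM

All three numbers come from a functional assay on MCF7 cells (Homo sapiens) for cytotoxicity, read by MTT assay, with a stated time of 72 h (a lower number here means a stronger inhibitor, a higher number a weaker inhibitor), and all three lie within the scatter of one another, so no order among them can be read. One structural change is already paired: fluoro in place of methyl on an aromatic carbon gave a 1.0-fold higher number from compound 1 to compound 2 (0.01 log units; within the scatter), a flat step. The two cores differ by methoxy in place of hydrogen on an aromatic carbon, which gave a 1.1-fold lower number from compound 1 to compound 3 (0.04 log units; within the scatter), also flat.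

Compound 4 `COc1ccc2nc(-c3ccc(-n4c(C)ccc4-c4ccc(F)cc4)cc3)sc2c1` has not yet been measured in this assay. It stands to compound 3 as compound 2 stands to compound 1: fluoro in place of methyl on an aromatic carbon. The place lines of the two changes read the same word for word, so this is the same change made on the core of compound 3 rather than on the core of compound 1.

Expectation for compound 4 in this assay: because the earlier instance of this change gave a 1.0-fold higher number from compound 1 to compound 2 (0.01 log units; within the scatter), the step is expected to be a 1.0-fold higher number from compound 3 to compound 4 (0.01 log units; within the scatter), essentially flat. Compound 4 is therefore estimated at 2900 nM, with a plausible range from 1500 nM to 5800 nM. Two examples of a change are a thin base, and the range allows for that.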

Compound 4, half-maximal inhibitory concentration: 2800 nM
Compound 4: middle estimate off by 1.0-fold (0.02 log units), on the high side; measured number inside the range.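

Fluoro in place of methyl, read as 4-methylphenyl to 4-fluorophenyl, gave a 1.0-fold lower number from compound 3 to compound 4 (0.01 log units; within the scatter) in this assay, and this step agrees with its earlier instance: the same change on two cores in this assay, a 1.0-fold higher number (0.01 log units; within the scatter) from compound 1 to compound 2 and a 1.0-fold lower number (0.01 log units; within the scatter) from compound 3 to compound 4, 1.0-fold (0.02 log units) apart, within the scatter of two such steps

Methoxy in place of hydrogen, the other side of the same four-compound square, gave a 1.1-fold lower number from compound 2 to compound 4 (0.06 log units; within the scatter), and it agrees in the same way: the same change on two cores in this assay, a 1.1-fold lower number (0.04 log units; within the scatter) from compound 1 to compound 3 and a 1.1-fold lower number (0.06 log units; within the scatter) from compound 2 to compound 4, 1.0-fold (0.02 log units) apart, within the scatter of two such steps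

For the compounds shown here, all of these steps are flat, which shows only that a change with no readable effect on one of these two cores also had none on the other; it does not show that a step of real size would carry from one core to the other, and two cores are too few to support a rule for the series.

Still open, on these data alone, is whether an amine or a carboxylic acid in place of the fluoro would give a readable step on either core. Also open, as far as these compounds go, is whether a longer chain in place of the methoxy would leave the number as flat.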